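The compounds below may be only part of what the source reports. "The series", "measured", "known", "first", "only" and "open" are said of these compounds alone.

Series notes. Compound 1 `O=S(=O)(CC1=NCCS1)c1c(-c2ccccc2)noc1-c1ccccc1` carries the shared core with two phenyl groups and the sulfonyl-linked five-membered ring. In a functional assay, tested at 50 ug/mL (a lower number here means a weaker effect, a higher number a stronger effect of the compound at the concentration tested), compound 1 is recorded only as "not active" (no number reported), so no number stands against it and its place among the measured compounds cannot be fixed. Compound 2 `O=S(=O)(CC1=NCCS1)c1n[nH]cc1-c1ccccc1` is the same case: in this assay compound 2 is recorded as "not active" (no number reported). Going by the values given here, the one compound with a number is compound 3 `COc1ccc(C2=NOC(c3ccc(C)cc3)C2S(=O)(=O)CC2=NCCO2)cc1`, which in this assay gives 65.9%; compound 3 differs from compound 1 in several places at once, so no single step between measured compounds can be drawn.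

Compound 4 `O=S(=O)(CC1=NCCO1)c1c(-c2ccccc2)noc1-c1ccccc1` is the one yet to be measured. It differs from compound 1 in one place: a group of 5 heavy atoms (3 carbon, 1 nitrogen, 1 oxygen; one five-membered non-aromatic ring with 2 hetero atoms) in place of a group of 5 heavy atoms (3 carbon, 1 nitrogen, 1 sulfur; one five-membered non-aromatic ring with 2 hetero atoms), on a saturated chain carbon bound to a sulfonyl sulfur. Whether the ring with the oxygen, as it also occurs in compound 3, carries the activity or the other features of compound 3 do, the measured compounds do not separate. Among the compounds with values here, because compound 1 stands at "not active" (no number reported) there is no baseline to size a step in this assay against; an upward move is possible but no measured pair supports it. For compound 4 the estimated read-out in this assay is 20%, with a range from 0% to 55%, and a fair chance that the result is again reported without a number.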

Compound 4, a percentage reported as activity, at one concentration (the size of the read-out at that concentration, not a potency): 57.2%
The estimate for compound 4 lay 37.2 percentage points below the measured number; measured number outside the range, above it.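

In this assay, going by these compounds alone, compound 4 gives 57.2%, while compound 1 stands at "not active" (no number reported), so no step between compound 1 and compound 4 can be read. Going by these compounds, the size of any effect of exchanging the sulfur-containing five-membered ring for the oxygen-containing one in this assay remains open. No evidence bears on this result.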